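The source may hold more compounds than are shown below. What is called first, only, known or untested is meant among the compounds shown, and "the series" means these compounds.

Series notes. Compound 1 `N#Cc1c(C2CCCCC2)nc(S)[nH]c1=O` was run in an assay on isolated protein for inhibition of Rap guanine nucleotide exchange factor 4 (Homo sapiens), read by fluorescence and cAMP accumulation; a higher number here means a weaker inhibitor, a lower number a stronger inhibitor. In this assay compound 1 gives > 300000 nM, which is a limit of the assay and not a number. Compound 2 `Cc1ccc(C)c(CSc2nc(C3CCNCC3)c(C#N)c(=O)[nH]2)c1` in this assay gives > 300000 nM, likewise a limit. Compound 1 therefore stands at the limit of > 300000 nM in this assay, at which 2 of the 2 values shown sit, with nothing to set it apart from compound 2. Among the measured compounds shown here, no step between measured compounds can be computed. Compound 3 `N#Cc1c(C2CCCCC2)nc(SCC(=O)O)[nH]c1=O` differs from compound 1 by carboxymethyl in place of hydrogen on a sulfur. With both measured values sitting at the limit, the expected step is a number no higher from compound 1 to compound 3 (the limit leaves the size open), none beyond the scatter. Compound 3 is expected at 300000 nM, within 50000 nM to 1000000 nM, most likely again reported only as a limit.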

Compound 3, half-maximal inhibitory concentration: > 300000 nM
Compound 3 ended at the assay's limit; the forecaster's own chance of this, stated with the estimate: 80%; the middle value sits exactly at the limit.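

No step can be read from compound 1 to compound 3, because both stand at the same limit, which is not a number: the limit of > 300000 nM in this assay, at which 3 of the 3 values shown sit.

The compounds shown leave open whether carboxymethyl in place of hydrogen on a sulfur changes inhibition at all.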